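Swapping the cycloalkyl amine of compound 1 for an aminobenzyl group

A few compounds are considered here, and "the series" means these few. Any claim that something is new, unique, unknown or untested is made for them only; others in the source may bear on it.

Measured compounds:
compound 1, `CC1CCCC(Nc2ncnc3c2nnn3Cc2ccccc2)C1`, 770 nM
compound 2, `CC1CCCC(Nc2ncnc3c2nnn3Cc2ccccc2Cl)C1`, 102 nM
compound 3, `O=[N+]([O-])c1cccc(Nc2ncnc3c2nnn3Cc2ccccc2Cl)c1`, 3300 nM

All three numbers come from an assay on cell membranes for binding affinity to adenosine receptor A1 (Bos taurus), read by radioligand binding; a higher number here means a weaker inhibitor, a lower number a stronger inhibitor. Compound 1 stands second highest of the three: compound 2 sits lower by a 7.5-fold lower number from compound 1 to compound 2 (0.88 log units; beyond the scatter), while compound 3 sits higher, the two being separated by a 32-fold higher number from compound 2 to compound 3 (1.51 log units; beyond the scatter).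

The unmeasured compound 4, `Nc1ccc(CNc2ncnc3c2nnn3Cc2ccccc2)cc1`, departs from compound 1 at the amine nitrogen: 4-aminobenzyl in place of 3-methylcyclohexyl on a nitrogen on an aromatic ring. Within the data shown here, the one measured step that touches this nitrogen is the one from compound 2 to compound 3, where the same 3-methylcyclohexyl group left and an aromatic ring entered, and the number rose by a 32-fold higher number from compound 2 to compound 3 (1.51 log units; beyond the scatter). That step installed a 3-nitrophenyl ring directly on the nitrogen, whereas compound 4 gains a 4-aminobenzyl group, so it is only a partial guide. Still, the loss of the 3-methylcyclohexyl group is shared, and a rise in this assay is the more likely direction, though probably a smaller one than seen there.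

Compound 4 is therefore expected to give a higher number than compound 1, an estimated step of a 5.2-fold higher number from compound 1 to compound 4 (0.72 log units; beyond the scatter). The estimate for compound 4 in this assay is 4000 nM, with a range from 1000 nM to 16000 nM.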

Compound 4, inhibition constant: 9500 nM
Compound 4: the middle estimate sits 2.4-fold (0.38 log units) below what was measured; the measured number falls inside the stated range.
By their numbers in this assay, from the lowest: compound 2; then compound 1; then compound 3; then compound 4.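

Placing 4-aminobenzyl in place of 3-methylcyclohexyl on this nitrogen gave, in this assay, a 12-fold higher number from compound 1 to compound 4 (1.09 log units; beyond the scatter). The earlier step at this nitrogen, a 32-fold higher number from compound 2 to compound 3 (1.51 log units; beyond the scatter), put the aromatic ring directly on the nitrogen and carried the chloro substituent, whereas this one has a benzyl group and no chloro substituent, yet the number rose in both, so the rise is not confined to a ring attached directly to the nitrogen or to the chlorinated compounds. The data shown offer no measurement that accounts for this rise.

As far as these compounds go, what remains open is whether the rise follows from the aromatic ring, the added carbon link or the amine on that ring, a question that a plain benzyl group or a cyclohexyl group on this nitrogen would help to separate. Also open, from the compounds shown here alone, is whether the chloro substituent, which gave a 7.5-fold lower number from compound 1 to compound 2 (0.88 log units; beyond the scatter) with 3-methylcyclohexyl on the nitrogen, would lower the number in the same way with 4-aminobenzyl there.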